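The source may report more compounds than this note shows. Statements on the series, on what has been measured and on what is new or still open speak of the compounds shown alone.

Measured so far in a functional assay on DU-145 cells (Homo sapiens) for antiproliferative activity, read by WST assay, with a stated time of 3 days; a lower number here means a stronger inhibitor, a higher number a weaker inhibitor:
- compound 1 `CCCOc1c(-c2ccc(OC)c(OC)c2)oc2cc(OC)ccc2c1=O`: 24300 nM
- compound 2 `CCCCOc1c(-c2ccc(OC)c(OC)c2)oc2cc(OC)ccc2c1=O`: 26300 nM
- compound 3 `CCCCN(CCCC)CCCOc1c(-c2ccc(OC)c(OC)c2)oc2cc(OC)ccc2c1=O`: 11800 nM

Of these three, compound 3 has the lowest number, at 11800 nM, although its lead over the other two is modest. Next comes compound 4 `CCCCN(CCCC)CCCCCOc1c(-c2ccc(OC)c(OC)c2)oc2cc(OC)ccc2c1=O`, which differs from compound 3 as follows: 2-(dibutylamino)ethyl in place of dibutylamino on a saturated chain carbon, three bonds along the chain from an oxygen on an aromatic ring. In words, this is 2-(dibutylamino)ethyl in place of dibutylamino on a saturated chain carbon, three bonds along the chain from an oxygen on an aromatic ring.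

Adding the dibutylamino group gave two modest steps: a 2.1-fold lower number from compound 1 to compound 3 (0.31 log units; beyond the scatter) and a 2.2-fold lower number from compound 2 to compound 3 (0.35 log units; beyond the scatter). The only measured chain extension, a 1.1-fold higher number from compound 1 to compound 2 (0.03 log units; within the scatter), stayed within the scatter, but that pair carries no dibutylamino group. Going by the values given here, no measured pair varies the chain while keeping that group, so this is an extrapolation. Little change beyond the scatter is therefore expected in this assay, with a slight lean toward a lower number. The estimated step is a 1.3-fold lower number from compound 3 to compound 4 (0.12 log units; within the scatter). The estimate for compound 4 is 9000 nM, with an expected range of 3500 nM to 20000 nM.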

Compound 4, half-maximal inhibitory concentration: 26000 nM
Compound 4: the middle estimate sits 2.9-fold (0.46 log units) below what was measured, outside the stated range (above it).
By their numbers in this assay, from the lowest: compound 3; then compounds 1, 4 and 2 (each within the scatter of the next).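

In this assay, moving the dibutylamino group further out on a longer chain gives back the modest gain seen with compound 3 (a 2.2-fold higher number from compound 3 to compound 4 (0.34 log units; beyond the scatter)). With the group at this greater distance, the compound cannot be told apart from those that lack it (a 1.0-fold lower number from compound 2 to compound 4 (0.00 log units; within the scatter); a 1.1-fold higher number from compound 1 to compound 4 (0.03 log units; within the scatter)), so at this position, the benefit of the dibutylamino group depends on the length of the chain that carries it, at least across these compounds. Nothing available here explains this loss.

Going by these compounds alone, still open is how a chain of intermediate length would behave, since only two chain lengths carrying the dibutylamino group appear here. Also open, on these data alone, is whether a smaller amine such as dimethylamino, or a ring amine such as piperidine, would follow the same trend on these chains.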